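A few compounds are considered here, and "the series" means these few. Any claim that something is new, unique, unknown or untested is made for them only; others in the source may bear on it.

Measured compounds:
compound 1, `COc1cc(-c2nn(-c3cccc(NC(=O)Nc4cc(C(F)(F)F)cc(C(F)(F)F)c4)c3)cc2-c2ccncc2)ccc1Cl`: > 50000 nM
compound 2, `COc1cc(-c2nn(-c3cccc(NC(=O)Nc4ccc(Cl)c(Cl)c4)c3)cc2-c2ccncc2)ccc1Cl`: > 50000 nM
compound 3, `O=C(Nc1cccc(-n2cc(-c3ccncc3)c(-c3ccc(Cl)c(O)c3)n2)c1)Nc1ccc(Cl)c(Cl)c1`: > 32500 nM

In a functional assay on OVCAR-4 cells (Homo sapiens) for inhibition, read by sulforhodamine B assay, with a stated time of 48 h (a higher number here means that more compound is tolerated, a lower number that less compound is tolerated), compound 1 reaches only a limit, > 50000 nM. Compound 2 likewise gives only a limit in this assay, > 50000 nM. Compound 3 also stops at a limit, > 32500 nM. Compound 2 therefore stands at a limit, as do the two other values shown: two sit at the limit of > 50000 nM in this assay, at which 2 of the 3 values shown sit, and one at the limit of > 32500 nM in this assay, at which 1 of the 3 values shown sits. Compound 4, `COc1cc(-c2nn(-c3cccc(NC(=O)Nc4ccc(Cl)c(C(F)(F)F)c4)c3)cc2-c2ccncc2)ccc1Cl`, differs from compound 2 by trifluoromethyl in place of chloro on an aromatic carbon. Among the compounds with values here, the one measured step that bears on this, a step that the two limits leave unreadable from compound 2 to compound 3, has a size that cannot be read, since both of its ends are limits. Nothing measured thus points to a change in this assay beyond the scatter from compound 2 to compound 4, and the expected outcome is that compound 4 again reaches only a limit. Compound 4 is expected at 60000 nM, within 20000 nM to 200000 nM. The expected step, a step that the limit leaves unreadable from compound 2 to compound 4, lies within the scatter.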

Compound 4, concentration lethal to 50% of the cells: > 32500 nM
Compound 4 ended at the assay's limit (the forecaster's own chance of this, stated with the estimate: 80%); the middle value is on the limit's open side.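

Compound 2 and compound 4 both stop at limits in this assay, so the step between them cannot be read. The compounds shown leave open whether trifluoromethyl in place of chloro changes the result in this assay, and where the true values of all four compounds lie.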